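The source may hold more compounds than are shown below. What is called first, only, known or untested is meant among the compounds shown, and "the series" means these compounds.

Working notes on the series.

Compound 3 `O=C1/C(=C/c2ccccc2)CCC/C1=C\c1ccccc1[N+](=O)[O-]` and compound 2 `O=C1/C(=C/c2ccccc2)CCC/C1=C\c1ccc([N+](=O)[O-])cc1` are built from the same atoms joined differently; the difference between the two cores is not broken down here. In a functional assay on MOLT-4 cells (Homo sapiens) for cytotoxicity, with a stated time of 72 h (a higher number here means a weaker inhibitor, a lower number a stronger inhibitor), compound 3 gives 1480 nM, and in this assay compound 2 gives 8350 nM. Compound 1 `COc1ccc(/C=C2\CCC/C(=C\c3ccccc3[N+](=O)[O-])C2=O)cc1` arises from compound 3 by methoxy in place of hydrogen on an aromatic carbon; in this assay compound 1 gives 8900 nM, a step of a 6.0-fold higher number from compound 3 to compound 1 (0.78 log units; beyond the scatter). Compound 4 `COc1ccc(/C=C2\CCC/C(=C\c3ccc([N+](=O)[O-])cc3)C2=O)cc1` has not been measured; it arises from compound 2 by the same change, (methoxy in place of hydrogen on an aromatic carbon). Going by the values given here, only one earlier instance of this change exists, so the expectation rests on it alone, tempered because compound 2 already stands at 8350 nM. From compound 2 to compound 4 a step of a 3.0-fold higher number from compound 2 to compound 4 (0.48 log units; beyond the scatter) is expected. For compound 4 the estimate is 25000 nM, within 8000 nM to 80000 nM.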

Compound 4, half-maximal inhibitory concentration: 300000 nM
The estimate for compound 4 lay 12-fold (1.08 log units) below the measured number, and the stated range ends below it.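

Methoxy in place of hydrogen on an aromatic carbon raises the number in this assay on both cores, and the new step is a 36-fold higher number from compound 2 to compound 4 (1.56 log units; beyond the scatter). The direction of the change carries from one core to the other, but its size does not: the same change on two cores in this assay, a 6.0-fold higher number (0.78 log units; beyond the scatter) from compound 3 to compound 1 and a 36-fold higher number (1.56 log units; beyond the scatter) from compound 2 to compound 4, 6.0-fold (0.78 log units) apart, beyond the scatter of two such steps

Going by these compounds alone, with only two cores, this shows that the size of the step cannot be transferred between these two cores; it does not show what sets the size or how the change would behave on a third core. Still open, from the compounds shown here alone, is whether a hydroxyl, an amine or a carboxylic acid in the place of the methoxy would move the number in the same direction on both cores. Also open, going by these compounds, is whether the gap between the two steps would persist with a nitrile in the place of the nitro group.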